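Moving the branch in a butyl chain on the ring nitrogen

The source may report more compounds than this note shows. Statements on the series, on what has been measured and on what is new or still open speak of the compounds shown alone.

In a functional assay on the whole organism for antagonist activity, with Rattus norvegicus as the target (on this read-out higher numbers stand for an effect only at larger amounts of compound and lower numbers for an effect already at smaller amounts), compound 2 `CCC(C)n1cnc2c(NC3CC3)ncnc21` gives 13.5 mg/kg, the only number shown for it; one further record of compound 2 holds no single figure. A close relative, compound 1 `CC(C1CC1)n1cnc2c(NC3CC3)ncnc21`, has three repeats in this assay and gives 2 mg/kg; 4.5 mg/kg; 12.5 mg/kg (3 entries); the spread among those repeats, (the several entries of compound 1 in this assay, 2 mg/kg; 4.5 mg/kg; 12.5 mg/kg (3 entries)), shows how widely a single compound can scatter here. Compound 3 `CC(C)Cn1cnc2c(NC3CC3)ncnc21` has not yet been measured. It differs from compound 2 by isobutyl in place of sec-butyl on an aromatic nitrogen. Among the compounds with values here, no measured pair in this set carries the same kind of change, so the step has to be anticipated rather than read off. The expectation is a small step, within or only just beyond the usual scatter, drifting if anything toward a somewhat larger dose. Compound 3 is therefore estimated at 16 mg/kg, within a range from 5 mg/kg to 45 mg/kg. The expected step from compound 2 to compound 3 is a 1.2-fold higher number from compound 2 to compound 3 (0.07 log units; within the scatter).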

Compound 3, dose for half-maximal effect: 10 mg/kg
The estimate for compound 3 lay 1.6-fold (0.20 log units) above the measured number, within the range that was stated.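

In this assay, isobutyl in place of sec-butyl on the aromatic nitrogen gives a 1.4-fold lower number from compound 2 to compound 3 (0.13 log units; within the scatter). Within the data shown here, this is the first step that can be read at this position, and it shows that shifting the branch within the butyl chain, with the same atoms kept, does not separate compound 2 from compound 3 on this read-out. Even a clearly larger step would need care, because repeats of a single compound spread widely here: the several entries of compound 1 in this assay, 2 mg/kg; 4.5 mg/kg; 12.5 mg/kg (3 entries)

What the compounds shown leave open is whether an unbranched butyl chain, a longer chain such as pentyl, or a chain ending in an amine would behave in the same way on this nitrogen. They also leave open whether any change at this position gives a step beyond the scatter.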